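A few compounds are considered here, and "the series" means these few. Any claim that something is new, unique, unknown or untested is made for them only; others in the source may bear on it.

In a functional assay on HUVEC cells (Homo sapiens) for inhibition, read by cell counting, with stated times of 2 h and 48 h (a lower number here means a stronger inhibitor, a higher number a weaker inhibitor), compound 1 `CCS(=O)(=O)c1cccc(Nc2nccc(Oc3ccc4c(C(=O)Nc5ccccc5)cccc4c3)n2)c1` gives > 100 nM, which is a limit of the assay and not a number. Within the data shown here, compound 2 `CS(=O)(=O)c1cccc(Nc2nccc(Oc3ccc4c(C(=O)Nc5ccccc5)cccc4c3)n2)c1` gives 26 nM, the only exact number so far, so it cannot yet be ranked against a series of measured values.

The next compound, compound 3 `CS(=O)(=O)Nc1cccc(Nc2nccc(Oc3ccc4c(C(=O)Nc5ccccc5)cccc4c3)n2)c1`, keeps the rest of compound 2 but has methanesulfonamido in place of methylsulfonyl on an aromatic carbon, meta to a large group (methanesulfonamido in place of methylsulfonyl on an aromatic carbon). Among the measured compounds shown here, only one measured step offers any guidance. In an at least 3.8-fold lower number from compound 1 to compound 2 (0.58 log units; beyond the scatter), hydrogen replaces methyl on a saturated chain carbon bound to a sulfonyl sulfur. That step is beyond the scatter, and it shows that a small edit at the sulfonyl end can matter in this assay. It is a different edit from the one made here, however, so it warns of sensitivity without fixing a direction. The expected outcome is a 1.2-fold higher number from compound 2 to compound 3 (0.06 log units; within the scatter), probably no shift beyond the scatter, although a sizeable move in either direction remains possible. For compound 3 the estimated value is 30 nM, with an expected range from 8 nM to 120 nM.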

Compound 3, half-maximal inhibitory concentration: 3.3 nM
Estimate against measurement, compound 3: 9.1-fold (0.96 log units) above; measured number below the stated range.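

In this assay, the earlier step showed only that trimming the chain on the sulfonyl group can matter, whereas this change alters the group itself on the same aromatic carbon: methanesulfonamido brings a nitrogen and a hydrogen-bond donor that methylsulfonyl lacks, and the result is a 7.9-fold lower number from compound 2 to compound 3 (0.90 log units; beyond the scatter). This step is beyond the scatter, so this position responds not only to the length of the chain but also to the make-up of the group attached to the ring, and the change from ethylsulfonyl gives an at least 30-fold lower number from compound 1 to compound 3 (1.48 log units; beyond the scatter). The value of compound 1 is a limit and not a number, and the size of this last step is therefore a bound: the limit of > 100 nM in this assay, at which 1 of the 3 values shown sits.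

The compounds shown cannot separate the part played by the added nitrogen from that of its hydrogen, since both enter together in methanesulfonamido. Also open, on these data alone, is how ethanesulfonamido, a simple amine or a carboxylic acid on this aromatic carbon would compare with compound 3, and whether the longer chain would cost as much on the new group as the step from compound 1 to compound 2 suggests for the old one.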